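Moving a Hydroxyl Group: What to Expect for Compound 4

The source may hold more compounds than are shown below. What is called first, only, known or untested is meant among the compounds shown, and "the series" means these compounds.

Three compounds built on one shared core were tested in an assay on isolated protein for inhibition of DNA topoisomerase 1 (Homo sapiens), with a stated time of 30 min, tested at 100 uM; on this read-out lower numbers stand for a weaker effect and higher numbers for a stronger effect at the one concentration tested. Compound 1 `Oc1cccc(-c2cc(-c3cccs3)cc(-c3ccccc3O)n2)c1` gives 83.2% in this assay. Compound 2 `Oc1ccc(-c2cc(-c3cccs3)cc(-c3ccccc3O)n2)cc1` gives 72.2%, and compound 3 `Oc1cccc(-c2cc(-c3ccsc3)cc(-c3ccccc3O)n2)c1` gives 10.2%, the lowest of the three. The change from compound 1 to compound 2 is 4-hydroxyphenyl in place of 3-hydroxyphenyl on an aromatic carbon, and it made a step of a number 11 percentage points lower from compound 1 to compound 2 (beyond the scatter). The change from compound 1 to compound 3 is thiophen-3-yl in place of thiophen-2-yl on an aromatic carbon, with a step of a number 73 percentage points lower from compound 1 to compound 3 (beyond the scatter).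

Compound 4 `Oc1ccc(-c2cc(-c3ccsc3)cc(-c3ccccc3O)n2)cc1` has not yet been measured. It differs from compound 3 by 4-hydroxyphenyl in place of 3-hydroxyphenyl on an aromatic carbon, the same kind of change as that from compound 1 to compound 2, though around the place the group sits meta to a thiophen-3-yl group rather than meta to a thiophen-2-yl group. If this kind of change behaves as before, a small drop is expected, so compound 4 is estimated at 5% in this assay, a step of a number 5.2 percentage points lower from compound 3 to compound 4 (within the scatter). That rests on compound 3 giving 10.2%, which leaves little room for a further fall, and on the modest step of a number 11 percentage points lower from compound 1 to compound 2 (beyond the scatter). For compound 4 the expected range runs from 0% to 25%.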

Compound 4, a percentage reported as inhibition, at one concentration (the size of the read-out at that concentration, not a potency): 13.8%
Estimate against measurement, compound 4: 8.8 percentage points below; the measured number falls inside the stated range.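

In this assay, 4-hydroxyphenyl in place of 3-hydroxyphenyl now gives a number 3.6 percentage points higher from compound 3 to compound 4 (within the scatter), and this does not match the step seen on the core carrying thiophen-2-yl: the same change on two cores in this assay, a number 11 percentage points lower (beyond the scatter) from compound 1 to compound 2 and a number 3.6 percentage points higher (within the scatter) from compound 3 to compound 4, 14.6 percentage points apart, beyond the scatter of two such steps. Thiophen-3-yl in place of thiophen-2-yl gives a number 58.4 percentage points lower from compound 2 to compound 4 (beyond the scatter), again a large step down, yet its size also depends on the core: the same change on two cores in this assay, a number 73 percentage points lower (beyond the scatter) from compound 1 to compound 3 and a number 58.4 percentage points lower (beyond the scatter) from compound 2 to compound 4, 14.6 percentage points apart, beyond the scatter of two such steps. So in these two pairs the thiophen change kept its direction but not its size, while the hydroxyl change cannot be carried from one core to the other as a fixed step; with only two examples of each change, this gives no rule for the wider series and does not show why the steps differ.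

From the compounds shown here alone, all four compounds keep the 2-hydroxyphenyl group and a hydroxyl on the other phenyl ring, so it remains open how the read-out would respond to a methoxy group or an amine in place of either hydroxyl. The numbers for the four compounds also come from a single concentration, so they tell only of a stronger or weaker effect at that concentration.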